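The source may report more compounds than this note shows. Statements on the series, on what has been measured and on what is new or still open speak of the compounds shown alone.

Measured compounds and their values in a functional assay on MCF7 cells (Homo sapiens) for antiproliferative activity, read by MTT assay, with a stated time of 72 h; a higher number here means a weaker inhibitor, a lower number a stronger inhibitor:

Compound 1 `O=C1OCC[C@@H]1NC(=S)SCCOc1cccc2ccccc12` gives > 64000 nM, a limit of the assay and not a number.
Compound 2 `COc1ccccc1/C=C/C(=O)c1ccc(OCC(=O)N[C@H]2CCOC2=O)cc1` gives > 64000 nM, likewise a limit of the assay.
Compound 3 `C=CCc1ccc(OCCSC(=S)N[C@H]2CCOC2=O)c(OC)c1` gives > 64000 nM, again a limit of the assay.

Compound 2 thus stands at the limit of this assay rather than at a measured number, and the other two compounds give only limits as well; all three values sit at the same point, namely (the limit of > 64000 nM in this assay, at which 3 of the 3 values shown sit). Going by the values given here, no step between measured compounds can be read from these data, so nothing is known here about how any structural change moves the read-out.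

Compound 4 `O=C(COc1ccc(C(=O)/C=C/c2ccccc2)cc1)N[C@H]1CCOC1=O` differs from compound 2 by hydrogen in place of methoxy on an aromatic carbon, in words a hydrogen in place of methoxy on an aromatic carbon. With compound 2 giving only a limit, the size of the step is expected to be none beyond the scatter: the estimated step from compound 2 to compound 4, a step that the limit leaves unreadable from compound 2 to compound 4, rests on the expectation that compound 4 also ends at the limit of this assay. Compound 4 is therefore expected to give about 80000 nM in this assay, with a range from 20000 nM to 300000 nM, and most likely only a limit will be reported.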

Compound 4, half-maximal inhibitory concentration: > 64000 nM
Compound 4: no number, only a limit; the forecaster's own chance of this, stated with the estimate: 85%; the middle value does not contradict the limit.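

Compound 2 and compound 4 both give only a limit in this assay, so no step can be read for hydrogen in place of methoxy on an aromatic carbon: the limit of > 64000 nM in this assay, at which 4 of the 4 values shown sit.

The compounds shown leave open which structural change, if any, would bring a numerical value in this assay.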